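Indole sulfonamide amides: cytotoxicity notes, compound 3 to compound 4

The source may report more compounds than this note shows. Statements on the series, on what has been measured and on what is new or still open speak of the compounds shown alone.

Measured so far in an ADME assay on MT4 cells (Homo sapiens) for cytotoxicity, read by MTT assay; on this read-out lower numbers stand for higher toxicity in this test and higher numbers for lower toxicity in this test:
compound 1 `Cc1cc(C)cc(S(=O)(=O)c2c(C(=O)NCc3cccc(N)c3)[nH]c3ccc(Cl)cc23)c1`: > 53400 nM
compound 2 `Cc1cc(C)cc(S(=O)(=O)c2c(C(=O)NCC(=O)NCc3ccncc3)[nH]c3ccc(Cl)cc23)c1`: > 48900 nM
compound 3 `Cc1cc(C)cc(S(=O)(=O)c2c(C(=O)NCc3ccc4nc(N)[nH]c4c3)[nH]c3ccc(Cl)cc23)c1`: 5890 nM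

Compound 1 shows a limit of this assay. Compound 2 likewise shows a limit of this assay. Compound 3 alone gives a number, the two others stop at limits the limit of > 48900 nM in this assay, at which 1 of the 3 values shown sits, and (the limit of > 53400 nM in this assay, at which 1 of the 3 values shown sits). The steps of an at least 9.0-fold lower number from compound 1 to compound 3 (0.95 log units; beyond the scatter) and an at least 8.3-fold lower number from compound 2 to compound 3 (0.91 log units; beyond the scatter) both point toward higher toxicity for the 2-amino-1H-benzimidazol-6-yl group.

Compound 4 `Cc1cc(C)cc(S(=O)(=O)c2c(C(=O)NCC(=O)NC(C)c3ccncc3)[nH]c3ccc(Cl)cc23)c1` reverses that change: (1-(pyridin-4-yl)ethyl)carbamoyl in place of 2-amino-1H-benzimidazol-6-yl on a saturated chain carbon bound to an amide-type nitrogen. It resembles compound 2 in its pyridinyl carbamoyl chain. Given an at least 8.3-fold lower number from compound 2 to compound 3 (0.91 log units; beyond the scatter), the step back is expected to be at least modest toward a higher number, probably ending at a limit again. Compound 4 is therefore estimated at 50000 nM (range 20000 nM to 110000 nM). This is expected to mean an 8.5-fold higher number from compound 3 to compound 4 (0.93 log units; beyond the scatter).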

Compound 4, half-maximal cytotoxic concentration: 47000 nM
For compound 4 the middle estimate is 1.1-fold (0.03 log units) above the measured one; low and high end bracket the measured number.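

In this assay, among the compounds shown here, leaving the 2-amino-1H-benzimidazol-6-yl group gives an 8.0-fold higher number from compound 3 to compound 4 (0.90 log units; beyond the scatter), the first step at this position with a measured number at both ends. Only floors can be read for an at least 1.0-fold lower number from compound 2 to compound 4 (0.01 log units; that floor lies within the scatter) and for an at least 1.1-fold lower number from compound 1 to compound 4 (0.05 log units; that floor lies within the scatter), so methyl in place of hydrogen on the saturated chain carbon shows no readable change. Compound 2 stops at a limit: the limit of > 48900 nM in this assay, at which 1 of the 4 values shown sits.

Open, from the compounds shown here alone, is whether a carboxylic acid or a longer chain at this position would keep the number as high as in compound 4. Also open, going by these compounds, is whether a benzimidazolyl group without its amine would give a number as low as in compound 3.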